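The compounds below may be only part of what the source reports. "The series", "measured", "known", "first", "only" and "open" are said of these compounds alone.

Compound 1 `Clc1ccc(-c2cc(-c3ccoc3)cc(-c3ccco3)n2)s1`: in a functional assay on DU-145 cells (Homo sapiens) for cytotoxicity, read by ELISA, with a stated time of 4 days (on this read-out lower numbers stand for stronger inhibition and higher numbers for weaker inhibition), compound 1 gives 17200 nM.
Compound 2 `Cc1cccc(-c2cc(-c3ccoc3)cc(-c3ccc(Cl)s3)n2)c1`: in this assay compound 2 gives 20300 nM.
Compound 3 `Clc1ccc(-c2cc(-c3ccoc3)cc(-c3ccc(Cl)s3)n2)cc1`: in this assay compound 3 gives 29500 nM.

All three compounds share one core and differ only in the group carried at a single aromatic carbon. Compound 1 holds the smallest of the three numbers, but this says little: the step of a 1.2-fold higher number from compound 1 to compound 2 (0.07 log units; within the scatter) and the step of a 1.7-fold higher number from compound 1 to compound 3 (0.23 log units; within the scatter) are both within the usual scatter of repeated measurements, as is the step of a 1.5-fold higher number from compound 2 to compound 3 (0.16 log units; within the scatter). So the three groups tried at this position so far cannot be told apart by their measurements.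

Compound 4 `Clc1ccc(-c2cc(-c3ccoc3)cc(-c3cccnc3)n2)s1` changes the same position once more: pyridin-3-yl in place of furan-2-yl on an aromatic carbon. The three measured steps all concern swaps at this very carbon, and none of them moved the number beyond the scatter, whether a five-membered ring was replaced by a six-membered ring or one six-membered ring by another. On that basis the change to compound 4 is expected to give no step beyond the scatter either, in this assay.

The estimate for compound 4 is therefore 19000 nM, with a range from 9000 nM to 40000 nM, which means an expected step of a 1.1-fold higher number from compound 1 to compound 4 (0.04 log units; within the scatter).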

Compound 4, half-maximal inhibitory concentration: 18500 nM
Compound 4: middle estimate off by 1.0-fold (0.01 log units), on the high side; the range from low to high includes it.
By their numbers in this assay, from the lowest: compounds 1, 4, 2 and 3 (each within the scatter of the next).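

Pyridin-3-yl is the first six-membered ring at this carbon to carry a ring nitrogen, and in this assay this new feature produces no step that can be told from noise, whether compound 4 is set against the furan-2-yl compound (a 1.1-fold higher number from compound 1 to compound 4 (0.03 log units; within the scatter)), the 4-chlorophenyl compound (a 1.6-fold lower number from compound 3 to compound 4 (0.20 log units; within the scatter)) or the 3-methylphenyl compound (a 1.1-fold lower number from compound 2 to compound 4 (0.04 log units; within the scatter)). The four groups at this carbon, next to the ring nitrogen of the shared core, therefore cannot be separated by these measurements, even though they include a five-membered ring with oxygen, plain six-membered rings bearing chlorine or methyl, and now a six-membered ring with nitrogen. Nothing available here explains this flat picture.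

Every group shown at this carbon is an aromatic ring, so it remains open whether a non-aromatic group, such as an amine, a carboxylic acid or a longer alkyl chain, would shift the number beyond the scatter. The compounds also leave open what happens when the furan-3-yl group or the 5-chlorothiophen-2-yl group is replaced while pyridin-3-yl stays in place.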